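Thiophen-3-yl in place of pyridin-3-yl on a shared core

This account rests on a few compounds, and the source may have more. Where it says the series, first, only, none or still open, it means among the compounds named here.

compound 1 `COC(=O)C1=C(C)NC(C)=C(C(=O)OC)C1c1c(-c2cccnc2)nc2sc(C)cn12` 12500 nM
compound 2 `COC(=O)C1=C(C)NC(C)=C(C(=O)OC)C1c1c(-c2ccccn2)nc2sccn12` 24400 nM
compound 3 `COC(=O)C1=C(C)NC(C)=C(C(=O)OC)C1c1c(-c2cccs2)nc2sccn12` 1300 nM

In a functional assay on cardiac atrium (Cavia porcellus) (a lower number here means that less compound is needed, a higher number that more compound is needed for the effect), compound 1 and compound 2 lie within the scatter of each other, while compound 3 has the lowest number of the three. Compound 4 `COC(=O)C1=C(C)NC(C)=C(C(=O)OC)C1c1c(-c2ccsc2)nc2sc(C)cn12` carries thiophen-3-yl in place of pyridin-3-yl on an aromatic carbon of the core of compound 1 thiophen-3-yl in place of pyridin-3-yl on an aromatic carbon with nothing else changed. For the measured compounds named here, one measured step bears on this, the large and beyond-scatter a 19-fold lower number from compound 2 to compound 3 (1.27 log units; beyond the scatter) for thiophen-2-yl in place of pyridin-2-yl on an aromatic carbon. That pair has a different core and a different attachment, so a lower but somewhat smaller change is expected in this assay here. The expected step is a 6.9-fold lower number from compound 1 to compound 4 (0.84 log units; beyond the scatter) as an estimate only. For compound 4 the estimate is 1800 nM with an expected range from 500 nM to 6500 nM as the likely span.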

Compound 4, half-maximal effective concentration: 2300 nM
Beside the measured number, compound 4's estimate is 1.3-fold (0.11 log units) below it; the range from low to high includes it.
By their numbers in this assay, from the lowest: compounds 3 and 4 (each within the scatter of the next); then compounds 1 and 2 (each within the scatter of the next).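

In this assay, thiophen-3-yl in place of pyridin-3-yl on this aromatic carbon gives a 5.4-fold lower number from compound 1 to compound 4 (0.74 log units; beyond the scatter), a modest step. The earlier large step came from the thiophen-2-yl and pyridin-2-yl pair on a different core, and this result shows the same direction on the core of compound 1 with a different attachment. Nothing measured here accounts for the step. As far as these compounds go, whether phenyl or furan-3-yl at this place would give a similar number remains open. So does whether an amine on the thiophen-3-yl ring would shift it.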